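A few compounds are considered here, and "the series" means these few. Any claim that something is new, unique, unknown or untested is made for them only; others in the source may bear on it.

Of the compounds shown here, two built on a shared core have so far been tested in an ADME assay on L6 cells (Rattus norvegicus) for cytotoxicity, read by resazurin assay, with a stated time of 72 h; a lower number here means a stronger inhibitor, a higher number a weaker inhibitor. Compound 1, `C/C(=N\N=C(/N)CC(O)c1cccc2ccccc12)c1ccc(F)cc1`, gives 34000 nM in this assay. Compound 2, `N/C(CC(O)c1cccc2ccccc12)=N\N=C\c1ccc(C(F)(F)F)cc1`, gives 26000 nM in this assay. Compound 2 has the lower of the two numbers, but the gap to compound 1 lies within the scatter of repeated measurements, so the two cannot be told apart on these figures. No single change connects them, since they differ in more than one place, and their two values are all that can be said of the pair.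

Compound 3, `N/C(CC(O)c1cccc2ccccc12)=N\N=C\c1ccccc1`, has not yet been measured in this assay. It differs from compound 2 in one place: hydrogen in place of trifluoromethyl on an aromatic carbon. Among the measured compounds shown here, no measured pair shows what this change does here, and the two values in hand are close to each other. A small step is expected, if anything toward a higher number, estimated at a 1.3-fold higher number from compound 2 to compound 3 (0.13 log units; within the scatter). Compound 3 is therefore expected to give about 35000 nM, with a likely range from 15000 nM to 80000 nM.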

Compound 3, half-maximal inhibitory concentration: 17000 nM
Beside the measured number, compound 3's estimate is 2.1-fold (0.31 log units) above it; measured number inside the range.
By their numbers in this assay, from the lowest: compounds 3, 2 and 1 (each within the scatter of the next).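

Hydrogen in place of trifluoromethyl on the aromatic carbon is the first single-place step measured on this core, and in this assay it amounts to a 1.5-fold lower number from compound 2 to compound 3 (0.18 log units; within the scatter) for this swap. Compound 2 and compound 3 therefore cannot be told apart, even though a group of four heavy atoms is gone from the ring, so in this pair the reading in L6 cells does not depend on trifluoromethyl being present at this position. Nothing at hand bears on why the step has this size.

Going by these compounds, only two substituents have been compared at this position, so it remains open whether another group on the same aromatic carbon, such as an amine, a carboxylic acid or a methoxy group, would give a number clearly separated from those of compound 2 and compound 3. On these data alone, it also remains open whether other parts of the shared core, such as the hydroxyl group on the chain, matter more for this reading than this position does.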